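Swapping the methyl of compound 2 for a nitro group

The source may report more compounds than this note shows. Statements on the series, on what has been measured and on what is new or still open speak of the compounds shown alone.

Compound 1 `CC(O)(C(=O)Nc1ccc(S(=O)(=O)c2cccc(F)c2)cc1)C(F)(F)F` gives 3400 nM in a functional assay (Cavia porcellus) with sulfonylurea receptors; K-ATP channels (Homo sapiens) as the target; on this read-out lower numbers stand for stronger inhibition and higher numbers for weaker inhibition. Compound 2 `Cc1ccc(S(=O)(=O)c2ccc(NC(=O)C(C)(O)C(F)(F)F)cc2)cc1` gives > 30000 nM in this assay, which is a limit of the assay and not a number (the limit of > 30000 nM in this assay, at which 1 of the 2 values shown sits). Among the compounds with values here, the one measured step, an at least 8.8-fold higher number from compound 1 to compound 2 (0.94 log units; beyond the scatter), therefore only sets a floor on the loss. Compound 3 `CC(O)(C(=O)Nc1ccc(S(=O)(=O)c2ccc([N+](=O)[O-])cc2)cc1)C(F)(F)F` carries nitro in place of methyl on an aromatic carbon. Within the data shown here, no measured pair covers a methyl-to-nitro exchange, so the step from compound 2 to compound 3 cannot be sized from the series; the only anchor is that compound 2 sits at the limit, so any movement from it can be read solely toward lower numbers. The step in this assay from compound 2 is expected to be an at least 1.5-fold lower number from compound 2 to compound 3 (0.17 log units; that floor lies within the scatter). Compound 3 is estimated at 20000 nM, with a range from 5000 nM to 60000 nM, and a fair chance that this assay again reports only a limit.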

Compound 3, half-maximal inhibitory concentration: > 30000 nM
Compound 3: only a limit was reported (the forecaster's own chance of this, stated with the estimate: 50%); middle value at least 1.5-fold (0.17 log units) away from the limit.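

In this assay the change to the 4-nitrophenyl group gives an at least 8.8-fold higher number from compound 1 to compound 3 (0.94 log units; beyond the scatter) and so repeats, with a second and different group, the loss seen for the 4-methylphenyl group. Compound 2 and compound 3 both end at a limit of the assay, so the step between them cannot be read and no order between methyl and nitro can be stated. With either group in this place, the read-out gives no measurable number, and the series now rests largely on limits: the limit of > 30000 nM in this assay, at which 2 of the 3 values shown sit.

The compounds shown do not separate moving the substituent on the ring from changing it, which a 4-fluorophenyl or a 3-nitrophenyl group would do. On these data alone, whether an amine or a carboxylic acid in this place would bring back a measurable number also remains open.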